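Series notes: removing chloro from compound 1

The source may report more compounds than this note shows. Statements on the series, on what has been measured and on what is new or still open speak of the compounds shown alone.

The three measured compounds share one core. Compound 1 `CC(C)(C)Cc1c(-c2ccc(Cl)cc2)sc(N)c1C(=O)c1ccc(Cl)cc1` is tested in an assay on CHO cells for displacement of a labelled ligand from adenosine receptor A3 (Homo sapiens), read by scintillation counting, tested at 10 uM (a lower number here means less inhibition, a higher number more inhibition at the concentration tested (going by the name of the read-out)), and gives 1%. Compound 2 `CC(C)(C)Cc1c(Br)sc(N)c1C(=O)c1ccc(Cl)c(Cl)c1` gives 1%, and compound 3 `CC(C)(C)Cc1c(Br)sc(N)c1C(=O)c1cccc(C(F)(F)F)c1` gives 4%. Compound 1 stands level with compound 2 at the digits shown, the pair together the lowest of the three numbers, and the gap to compound 3 lies within the scatter, so no order among the three can be read. Compound 4 `CC(C)(C)Cc1c(-c2ccccc2)sc(N)c1C(=O)c1ccc(Cl)cc1` differs from compound 1 by hydrogen in place of chloro on an aromatic carbon. Within the data shown here, no step between measured compounds is available in this set. With all three measured values close to the floor of the read-out, the expected step of a number 2 percentage points higher from compound 1 to compound 4 (within the scatter) is none beyond the scatter. Compound 4 is therefore estimated at 3%, with a range from -6% to 14%.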

Compound 4, a percentage reported as inhibition, at one concentration (the size of the read-out at that concentration, not a potency): 1%
The estimate for compound 4 lay 2 percentage points above the measured number; the measured number falls inside the stated range.
By their numbers in this assay, from the lowest: compounds 1, 2, 4 and 3 (each within the scatter of the next).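

In this assay, among these compounds, the first single-place comparison gives no change at the digits printed from compound 1 to compound 4 (within the scatter) on going from 4-chlorophenyl to phenyl. Chloro on this aromatic carbon, para to a large group, is therefore not required for the read-out to stay at this level, although a result this close to the floor of the read-out says little more. Nothing available explains this result. From the compounds shown here alone, whether any group at this carbon can shift the number remains open, and an amine or a carboxylic acid there would test that. Also open, going by these compounds, is whether any change to the shared core gives a number clear of the scatter.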